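The source may hold more compounds than are shown below. What is called first, only, known or untested is meant among the compounds shown, and "the series" means these compounds.

Compound 1 `CN[C@@H]1CCN(c2c(F)cc3c(=O)c(C(=O)O)cn(Cc4ccc(-c5ccccc5)cc4)c3c2OC)C1` gives 57700 nM in an assay on isolated protein for inhibition of DNA topoisomerase 1 (Homo sapiens), with a stated time of 15 min; a higher number here means a weaker inhibitor, a lower number a stronger inhibitor. Compound 2 `CNCCNc1cc2c(cc1F)c(=O)c(C(=O)O)cn2Cc1ccc(-c2ccccc2)cc1` gives only a limit in this assay, > 200000 nM. Compound 3 `CNCCNc1c(F)cc2c(=O)c(C(=O)O)cn(Cc3ccc(-c4ccccc4)cc3)c2c1OC` likewise gives only a limit in this assay, > 200000 nM.

Compound 2 therefore stands at the limit of this assay, a position it shares with compound 3 (the limit of > 200000 nM in this assay, at which 2 of the 3 values shown sit). The change to compound 4 `NC[C@@H]1CCN(c2cc3c(cc2F)c(=O)c(C(=O)O)cn3Cc2ccc(-c3ccccc3)cc2)C1` is 3-(aminomethyl)pyrrolidin-1-yl in place of (2-(methylamino)ethyl)amino on an aromatic carbon. Of the measured steps, an at least 3.4-fold higher number from compound 1 to compound 3 (0.53 log units; beyond the scatter) bears on it, since it shows that a pyrrolidinyl group at that carbon gives a lower number than the open chain. a step that the two limits leave unreadable from compound 2 to compound 3 is not readable, so the missing methoxy group gives no guidance. Compound 4 is therefore expected to give a readable number, estimated at 100000 nM (range 40000 nM to 200000 nM), a step of an at least 2.0-fold lower number from compound 2 to compound 4 (0.30 log units; that floor lies within the scatter).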

Compound 4, half-maximal inhibitory concentration: 15600 nM
Estimate against measurement, compound 4: 6.4-fold (0.81 log units) above; the measured number lies below the stated range.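

On the core without the methoxy group, this assay shows an at least 12-fold lower number from compound 2 to compound 4 (1.10 log units; beyond the scatter), so 3-(aminomethyl)pyrrolidin-1-yl at this aromatic carbon gives a readable number where (2-(methylamino)ethyl)amino gives only a limit. Within the data shown here, the advantage of a pyrrolidine-based group over the open chain, earlier seen only with methoxy present, therefore also appears without it. The size of this step remains a floor, since compound 2 sits at a limit: the limit of > 200000 nM in this assay, at which 2 of the 4 values shown sit.

As far as these compounds go, the step for methoxy in place of hydrogen cannot be read, so that group's contribution remains unknown. From the compounds shown here alone, it also remains open how a six-membered piperazin-1-yl group would fare at this carbon.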